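A few compounds are considered here, and "the series" means these few. Any claim that something is new, unique, unknown or untested is made for them only; others in the source may bear on it.

Measured so far: compound 1 `COc1cc(OC)cc(-c2ccc3c(c2)C(CC(=O)OCC2CO2)C(C(=O)OCC2CO2)=C(N)O3)c1`, compound 2 `CCOC(=O)CC1C(C(=O)OCC)=C(N)Oc2ccc(-c3ccc(F)cc3F)cc21`, compound 3 `C#CCOC(=O)CC1C(C#N)=C(N)Oc2ccc(-c3cccc(N)c3)cc21`.

In a functional assay on HL-60 cells (Homo sapiens) for cytotoxicity, read by CellTiter-Blue, with a stated time of 48 h (a higher number here means a weaker inhibitor, a lower number a stronger inhibitor), compound 1 gives > 80000 nM, a limit of the assay rather than a number. In this assay compound 2 gives 76600 nM. Compound 3 gives 43900 nM. Compound 2 thus holds the higher of the two numbers, but its neighbour compound 3 sits within the scatter of it. Compound 4 `CCOC(=O)CC1C(C(=O)OCC)=C(N)Oc2ccc(-c3cccc(NC)c3)cc21` has not yet been tested. It differs from compound 2 by 3-(methylamino)phenyl in place of 2,4-difluorophenyl on an aromatic carbon. Among the compounds with values here, no measured step covers this change, so the expectation rests on compound 3 with 43900 nM. A small downward step, within the scatter, is expected: a 1.5-fold lower number from compound 2 to compound 4 (0.19 log units; within the scatter). Compound 4 is expected near 50000 nM, between 20000 nM and 100000 nM.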

Compound 4, half-maximal inhibitory concentration: 7450 nM
Compound 4: the middle estimate sits 6.7-fold (0.83 log units) above what was measured; the measured number lies below the stated range.
By their numbers in this assay, from the lowest: compound 4; then compounds 3 and 2 (each within the scatter of the next). At a limit, above all of these: compound 1.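

In this assay, 3-(methylamino)phenyl in place of 2,4-difluorophenyl brings a 10-fold lower number from compound 2 to compound 4 (1.01 log units; beyond the scatter). Within the data shown here, this is the first step between compounds differing in one place, and it shows that a change on this aromatic carbon alone can move the number beyond the scatter. Nothing measured here gives a reason for the size of this step.

As far as these compounds go, whether the step follows the loss of the fluorines or the arrival of the methylamino group stays open. So does what a plain phenyl or a 3-(dimethylamino)phenyl would give on the core of compound 4.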